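The source may hold more compounds than are shown below. What is called first, only, known or untested is meant among the compounds shown, and "the series" means these compounds.

Three compounds share one core and differ only in the group on an aromatic carbon. Compound 1 `Cc1ccc2[nH]c(CC(CC(=O)O)c3ccc(Cl)cc3)nc2c1` carries a methyl there; in an assay on isolated protein for inhibition of protein kinase C zeta type (Homo sapiens), read by 33P incorporation, tested at 200 uM (a higher number here means a stronger effect of the compound at the concentration tested, a lower number a weaker effect), compound 1 gives 0%. Compound 2 `COc1ccc2[nH]c(CC(CC(=O)O)c3ccc(Cl)cc3)nc2c1` carries a methoxy in its place, and in this assay compound 2 gives 0%. Compound 3 `O=C(O)CC(Cc1nc2cc(C(=O)O)ccc2[nH]1)c1ccc(Cl)cc1` carries a carboxy, and in this assay compound 3 gives 0%. The steps among them are no change at the digits printed from compound 1 to compound 2 (within the scatter), no change at the digits printed from compound 1 to compound 3 (within the scatter) and no change at the digits printed from compound 2 to compound 3 (within the scatter); compound 3 thus stands level with compounds 1 and 2 at the digits shown, nearest to compound 1 and furthest from compound 2, both within the scatter.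

Compound 4 `COC(=O)c1ccc2[nH]c(CC(CC(=O)O)c3ccc(Cl)cc3)nc2c1` has not yet been measured. It differs from compound 3 by methyl in place of hydrogen on an oxygen next to a carbonyl group. Among the compounds with values here, no measured step touches this oxygen; the three steps that exist all exchange the group on the aromatic carbon, and none of them moved this assay beyond the scatter. With every exchange in this part of the molecule leaving the read-out flat, the expected step is no change beyond the scatter, namely no change at the digits printed from compound 3 to compound 4 (within the scatter). Compound 4 is therefore estimated at 0%, within -8% to 10%.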

Compound 4, a percentage reported as inhibition, at one concentration (the size of the read-out at that concentration, not a potency): 0%
Beside the measured number, compound 4's estimate shows no gap at the digits printed; low and high end bracket the measured number.
By their numbers in this assay, from the lowest: compounds 1, 2, 3 and 4 (each within the scatter of the next).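

Methyl in place of hydrogen on this oxygen, which turns carboxy into methoxycarbonyl, is the first change away from the aromatic carbon itself, and in this assay it gives no change at the digits printed from compound 3 to compound 4 (within the scatter), so the flat read-out holds for a change on this oxygen too. Methoxycarbonyl also reads level with the two other groups on the aromatic carbon, with no change at the digits printed from compound 2 to compound 4 (within the scatter) and no change at the digits printed from compound 1 to compound 4 (within the scatter), which makes four groups there, namely methyl, methoxy, carboxy and methoxycarbonyl, that cannot be told apart in this read-out. Nothing available explains why these groups give the same read-out.

Going by these compounds, since every step here stays within the scatter, these compounds do not show whether any group at this position can raise the read-out, and an amine or a primary amide on the aromatic carbon, or an ethyl group in place of the methyl on this oxygen, remains untested in this account. On these data alone, all four compounds also keep the rest of the shared core unchanged, so the effect of a change elsewhere in the molecule stays open.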